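Adding one hydroxy group to compound 2

A few compounds are considered here, and "the series" means these few. Any claim that something is new, unique, unknown or untested is made for them only; others in the source may bear on it.

Values in a functional assay on microsomes for inhibition, with a stated time of 1 h; a lower number here means a stronger inhibitor, a higher number a weaker inhibitor:
- Compound 1 `CSc1nc(-c2ccccc2O)c(C#N)c(=O)n1C`: 44 ug/mL
- Compound 2 `Cn1c(NN)nc(-c2ccccc2O)c(C#N)c1=O`: 34 ug/mL

Within the data shown here, compound 2 gives 34 ug/mL and stands level with the only other measured compound, since the step between them is a 1.3-fold lower number from compound 1 to compound 2 (0.11 log units; within the scatter). Compound 3 `Cn1c(NN)nc(-c2cccc(O)c2O)c(C#N)c1=O` differs from compound 2 by a single change: hydroxy in place of hydrogen on an aromatic carbon. In words, this is hydroxy in place of hydrogen on an aromatic carbon. Among the measured compounds shown here, the one measured step lies at a different place in the structure, and no measured pair shows what adding a hydroxy group does. It therefore offers no guide to direction, and no change beyond the scatter is expected in this assay, though a real shift either way remains possible. The expected step is a 1.1-fold lower number from compound 2 to compound 3 (0.05 log units; within the scatter). For compound 3 the estimated value is 30 ug/mL, with an expected range of 12 ug/mL to 75 ug/mL.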

Compound 3, half-maximal inhibitory concentration: 31 ug/mL
Compound 3: the middle estimate sits 1.0-fold (0.01 log units) below what was measured; low and high end bracket the measured number.
By their numbers in this assay, from the lowest: compounds 3, 2 and 1 (each within the scatter of the next).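

In this assay, putting a hydroxy group on this aromatic carbon, ortho to the hydroxy group already present, gives a 1.1-fold lower number from compound 2 to compound 3 (0.04 log units; within the scatter). Among these compounds, this is the first reading at this place in the structure, as the earlier step concerned the swap of methylsulfanyl for aminoamino elsewhere on the molecule. Here, the ring carbon takes an added hydroxy group with no change beyond the scatter, so the two neighbouring hydroxy groups read the same as one in this assay, and nothing available explains this result.

The compounds shown leave open whether a larger or differently built group at this carbon, such as a methoxy group, an amine or a carboxylic acid, would also leave the number in place. They also leave open whether adding the hydroxy group to compound 1 would give a similar result.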